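Replacing an isopropoxy group with bromo

The source may report more compounds than this note shows. Statements on the series, on what has been measured and on what is new or still open speak of the compounds shown alone.

Of the compounds shown here, three sharing one core have been measured so far. In a functional assay on SiHa cells (Homo sapiens) for antiproliferative activity, read by CCK-8 assay, with a stated time of 72 h (on this read-out lower numbers stand for stronger inhibition and higher numbers for weaker inhibition), compound 1 `COc1ccc(-c2cncnc2-c2cc(OC)c(OC)c(OC)c2)cc1` gives 2850 nM, and compound 2 `COc1ccc(-c2cncnc2-c2cc(OC)c(OC)c(OC)c2)cc1O` gives 2750 nM. Hydroxy in place of hydrogen on an aromatic carbon is the only difference between these two, and the step is a 1.0-fold lower number from compound 1 to compound 2 (0.02 log units; within the scatter). Compound 3 `COc1cc(-c2ncncc2-c2ccc(OC(C)C)cc2)cc(OC)c1OC` gives 9970 nM, the highest of the three numbers. Isopropyl in place of methyl on an oxygen on an aromatic ring separates it from the first compound, and that step is a 3.5-fold higher number from compound 1 to compound 3 (0.54 log units; beyond the scatter).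

Compound 4 `COc1cc(-c2ncncc2-c2ccc(Br)cc2)cc(OC)c1OC` has not been measured yet. It carries bromo in place of isopropoxy on an aromatic carbon. Going by the values given here, no measured compound carries bromo, so the data offer only indirect guidance. Among the compounds with values here, the one measured step at this place, a 3.5-fold higher number from compound 1 to compound 3 (0.54 log units; beyond the scatter), raised the number when the group on the oxygen grew. With the isopropoxy gone, a move back towards compound 1 at 2850 nM seems the likeliest outcome, though this is uncertain. The expected step is a 2.8-fold lower number from compound 3 to compound 4 (0.45 log units; beyond the scatter). For compound 4 the estimated value is 3500 nM, with an expected range from 1200 nM to 10000 nM.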

Compound 4, half-maximal inhibitory concentration: 2960 nM
Estimate against measurement, compound 4: 1.2-fold (0.07 log units) above, within the range that was stated.
By their numbers in this assay, from the lowest: compounds 2, 1 and 4 (each within the scatter of the next); then compound 3.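

In this assay the swap of isopropoxy for bromo gives a 3.4-fold lower number from compound 3 to compound 4 (0.53 log units; beyond the scatter) and so wins back what isopropoxy lost, while bromo in place of methoxy gives a 1.0-fold higher number from compound 1 to compound 4 (0.02 log units; within the scatter) and leaves those two level. An oxygen on this aromatic carbon is therefore not required for a number close to that of compound 1: bromo, a single heavy atom with no hydrogen-bond acceptor, does as well as methoxy, and of these groups only isopropoxy, with its 4 heavy atoms, stands apart. The 4-bromophenyl group also matches the 3-hydroxy-4-methoxyphenyl group, with a 1.1-fold higher number from compound 2 to compound 4 (0.03 log units; within the scatter) as the step, so compound 1, compound 2 and compound 4 form one level, and only compound 3 sits apart from it.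

The compounds shown leave open how chloro, an amine, a carboxylic acid or a longer chain such as butoxy would behave at this place. They also offer no measurement that could explain why isopropoxy stands apart from bromo and methoxy.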